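The compounds below may be only part of what the source reports. "The series", "measured", "known", "first", "only" and "open" are said of these compounds alone.

Measured in a functional assay on A-375 cells (Homo sapiens) for activation, with a stated time of 3 days; on this read-out higher numbers stand for an effect only at larger amounts of compound and lower numbers for an effect already at smaller amounts:

- compound 1 `O=C(Nc1ccc(-c2ncc[nH]2)cc1)C1CCCN(Cc2ccc(F)c(F)c2)C1`: 8000 nM
- compound 2 `O=C(Nc1ccc(-c2ccn[nH]2)cc1)C1CCCN(Cc2ccc(F)c(F)c2)C1`: 580 nM

For the measured compounds named here, compound 2, at 580 nM, holds the lower of the two numbers in this assay, and compound 1, at 8000 nM, is its only neighbour. Compound 3 `O=C(Nc1ccc(-c2ccsc2)cc1)C1CCCN(Cc2ccc(F)c(F)c2)C1` keeps the rest of compound 2 and alters one group: thiophen-3-yl in place of 1H-pyrazol-5-yl on an aromatic carbon. In words, thiophen-3-yl stands in place of 1H-pyrazol-5-yl on an aromatic carbon.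

Going by the values given here, one measured step bears on this change. It is a 14-fold lower number from compound 1 to compound 2 (1.14 log units; beyond the scatter), a large step beyond the scatter, made at the same place by exchanging one five-membered aromatic ring for another. It shows that the read-out can respond strongly to the ring at this place. However, neither measured compound carries thiophen-3-yl, so that step gives no direction for the new exchange. A sizeable move either way remains possible, but no shift is favoured. The step expected is a 1.2-fold lower number from compound 2 to compound 3 (0.06 log units; within the scatter), with a wide margin on both sides. For compound 3 the estimated value is 500 nM, with an expected range from 120 nM to 2500 nM.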

Compound 3, half-maximal effective concentration: 1930 nM
The estimate for compound 3 lay 3.9-fold (0.59 log units) below the measured number, within the range that was stated.
By their numbers in this assay, from the lowest: compound 2; then compound 3; then compound 1.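

In this assay, thiophen-3-yl on this aromatic carbon gives a 3.3-fold higher number from compound 2 to compound 3 (0.52 log units; beyond the scatter) and so does not match 1H-pyrazol-5-yl, although both are five-membered aromatic rings with the same count of 5 heavy atoms. Set against the imidazole, the same ring gives a 4.1-fold lower number from compound 1 to compound 3 (0.62 log units; beyond the scatter) and so places compound 3 in the middle of the three, which shows that a ring with 0 hydrogen-bond donors can still give a lower number than compound 1 while the best number here belongs to compound 2, whose ring has 1 hydrogen-bond donor. Nothing at hand accounts for this order among the three rings.

For the compounds shown here, with only three five-membered rings compared, it remains open whether the order reflects the donor count, the nitrogen atoms or some other feature of the ring, since compound 3 differs from compound 2 in several of these at once. From the compounds shown here alone, it is also open how this position would respond to a six-membered ring such as pyridine, or to an open group such as an amine or a carboxylic acid in place of the ring.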